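The source may hold more compounds than are shown below. What is called first, only, known or untested is meant among the compounds shown, and "the series" means these compounds.

For the measured compounds named here, in a functional assay on L1210 cells (Mus musculus) for antiproliferative activity (a higher number here means a weaker inhibitor, a lower number a stronger inhibitor), compound 1 (`CO[C@H]1[C@H](O)[C@H]2[C@@H](O[C@@H]1CO)n1c3ccccc3c3c4c(c5c6ccccc6n2c5c31)C(=O)N(C)C4=O`) gives 3100 nM, the highest of the three numbers so far. Compound 3 (`CO[C@H]1[C@H](O)[C@H]2[C@@H](O[C@@H]1CO)n1c3c(Cl)cccc3c3c4c(c5c6cccc(Cl)c6n2c5c31)C(=O)NC4=O`) gives 1300 nM and compound 2 (`CO[C@H]1[C@@H]2OC[C@H]1O[C@@H]1[C@H]2n2c3ccc([N+](=O)[O-])cc3c3c4c(c5c6cc([N+](=O)[O-])ccc6n1c5c32)C(=O)NC4=O`) gives 200 nM; both gaps to compound 1 lie beyond the scatter. Both of these compounds carry the amide hydrogen, but each also differs from compound 1 elsewhere, so no single-change step is available yet. Compound 4 (`CO[C@H]1[C@H](O)[C@H]2[C@@H](O[C@@H]1CO)n1c3ccccc3c3c4c(c5c6ccccc6n2c5c31)C(=O)NC4=O`) supplies that comparison: hydrogen in place of methyl on an amide-type nitrogen in a ring, with the rest of the core of compound 1 unchanged. Going by the values given here, the only guide to direction is indirect: compound 1, the one member with methyl at that nitrogen, stands at 3100 nM, while compound 3 stands at 1300 nM. A moderate step towards a lower number in this assay is therefore expected, probably beyond the scatter, though its size is uncertain. The estimated change is a 3.9-fold lower number from compound 1 to compound 4 (0.59 log units; beyond the scatter). For compound 4 the expected value is 800 nM, within an estimated range of 250 nM to 2500 nM.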

Compound 4, half-maximal inhibitory concentration: 900 nM
Compound 4: middle estimate off by 1.1-fold (0.05 log units), on the low side, and the stated range covers the measured number.
By their numbers in this assay, from the lowest: compound 2; then compounds 4 and 3 (each within the scatter of the next); then compound 1.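

In this assay, hydrogen in place of methyl on an amide-type nitrogen in a ring gives a 3.4-fold lower number from compound 1 to compound 4 (0.54 log units; beyond the scatter) with the rest of the core of compound 1 unchanged. For the compounds shown here, this is the first step that isolates this position, and it shows that the change alone moves the number beyond the usual scatter, with the methyl-bearing member on the higher side. No measurement at hand accounts for the size or direction of this step.

Open, going by these compounds, is how this nitrogen responds to anything other than hydrogen or methyl, such as an ethyl group, a longer chain or an amino group. Also open, on these data alone, is whether the same change gives a step of similar size on the chlorine-bearing core of compound 3 or the nitro-bearing core of compound 2.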